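The source may report more compounds than this note shows. Statements on the series, on what has been measured and on what is new or still open speak of the compounds shown alone.

Measured compounds:
compound 1 `CCCc1nn(C)c2c(NCc3ccc(F)cc3)nc(/C=C/c3cccnc3)nc12` — 940000 nM
compound 2 `COc1cc(/C=C/c2nc(NC3CC3)c3sccc3n2)cc(OC)c1OC` — > 1000000 nM

In a functional assay on L02 cells (Homo sapiens) for inhibition, read by Griess assay, with stated times of 1 h and 24 h (a higher number here means a weaker inhibitor, a lower number a stronger inhibitor), compound 1 gives 940000 nM. For compound 2 this assay returns only a limit, > 1000000 nM, so its position is known just from the limit of > 1000000 nM in this assay, at which 1 of the 2 values shown sits. Compound 3 `COc1ccc(CNc2nc(/C=C/c3cc(OC)c(OC)c(OC)c3)nc3ccsc23)cc1` differs from compound 2 by 4-methoxybenzyl in place of cyclopropyl on a nitrogen on an aromatic ring. Going by the values given here, no measured pair shows what such a change does here, and compound 1, which carries a benzyl group on its amine, sits close to that limit as well. The estimate is therefore for little movement beyond the scatter, an at least 1.1-fold lower number from compound 2 to compound 3 (0.04 log units; that floor lies within the scatter), and compound 3 is expected to give 900000 nM, between 300000 nM and 3000000 nM.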

Compound 3, half-maximal inhibitory concentration: > 1000000 nM
Compound 3 gave a limit, no number; the forecaster's own chance of this, stated with the estimate: 55%; middle value at least 1.1-fold (0.04 log units) from the limit.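

In this assay compound 3 returns only a limit, > 1000000 nM, and compound 2 is likewise held at a limit, so no step can be read between them. On these data alone, whether 4-methoxybenzyl in place of cyclopropyl changes inhibition at all stays open.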